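The source may hold more compounds than are shown below. What is called first, only, known or untested is meant among the compounds shown, and "the series" means these compounds.

Compound 1, `C#CCSc1nc(Sc2nccs2)c(C#N)c(-c2ccc(C)cc2)n1`: 1620 nM
Compound 2, `C#CCSc1nc(Sc2nc(C)c(C)s2)c(C#N)c(-c2cc(OC)c(OC)c(OC)c2)n1`: > 20000 nM

Of the compounds shown here, two sharing a common core have been tested in a functional assay on PC-3 cells (Homo sapiens) for antiproliferative activity, read by MTT assay, with a stated time of 72 h; a higher number here means a weaker inhibitor, a lower number a stronger inhibitor. Within the data shown here, compound 1 gives 1620 nM and is the only compound with an actual number. Compound 2 gives > 20000 nM, which is a limit of the assay and not a number; it sits at the limit of > 20000 nM in this assay, at which 1 of the 2 values shown sits. Compound 1 therefore stands alone as the one measured point from which to reason.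

Compound 3, `C#CCSc1nc(Sc2nccs2)c(C#N)c(-c2ccc(Cl)cc2)n1`, has not yet been tested. It differs from compound 1 in one place: chloro in place of methyl on an aromatic carbon. The chloro group enters on an aromatic carbon of a six-membered aromatic ring of carbon only, in place of the methyl that compound 1 carries there. Among the measured compounds shown here, no measured pair in this set isolates such a swap, so there is nothing to calibrate against.

The expectation is that the step of a 1.1-fold lower number from compound 1 to compound 3 (0.03 log units; within the scatter) stays within the usual scatter, with no clear direction. On that basis compound 3 is estimated at 1500 nM, with a likely range from 600 nM to 4000 nM.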

Compound 3, half-maximal inhibitory concentration: 3620 nM
Compound 3: middle estimate off by 2.4-fold (0.38 log units), on the low side; measured number inside the range.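

Measured in this assay, the change from 4-methylphenyl to 4-chlorophenyl gives a 2.2-fold higher number from compound 1 to compound 3 (0.35 log units; beyond the scatter) and makes compound 3 the weaker inhibitor of this pair. Among these compounds, this is the first pair here that differs in only one place, and it shows that the position para to a large group on the six-membered ring is not indifferent to what sits there: exchanging one heavy atom for another, with no ring, hydrogen-bond donor, hydrogen-bond acceptor or net charge involved on either side, is enough to move the number past the usual scatter. Nothing measured here accounts for why this exchange raises the number rather than lowering it.

From the compounds shown here alone, with only methyl and chloro compared at this position, it remains open how a fluoro group, an amine, a carboxylic acid or a longer chain would behave there, and whether the shift seen for chloro belongs to a wider pattern. Compound 2 gives > 20000 nM, which is a limit of the assay and not a number, and it differs from compound 1 in more than one place, so it isolates no single change.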